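Benzyl to propyl on the amine of compound 1

The source may report more compounds than this note shows. Statements on the series, on what has been measured and on what is new or still open speak of the compounds shown alone.

Within the data shown here, compound 1 `Cc1ccc(-c2cnc(N(Cc3ccccc3)Cc3ccc(C(=O)NO)cc3)s2)cc1` stands highest of the three numbers so far in a functional assay on HCT-116 cells (Homo sapiens) for antiproliferative activity, read by MTT assay, with a stated time of 48 h (a lower number here means a stronger inhibitor of growth, a higher number a weaker inhibitor of growth), where compound 1 gives 48800 nM. Compound 2 `CCN(Cc1ccc(C(=O)NO)cc1)c1ncc(-c2ccc(C)cc2)s1` gives 6870 nM in this assay, and compound 3 `Cc1ccc(-c2cnc(N(CCCOc3ccccc3)Cc3ccc(C(=O)NO)cc3)s2)cc1` gives 4140 nM. Both steps away from compound 1 lie beyond the scatter: a 7.1-fold lower number from compound 1 to compound 2 (0.85 log units; beyond the scatter) and a 12-fold lower number from compound 1 to compound 3 (1.07 log units; beyond the scatter). The remaining step, a 1.7-fold lower number from compound 2 to compound 3 (0.22 log units; within the scatter), stays within the scatter, so compound 2 and compound 3 are not separated here.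

Compound 4 `CCCN(Cc1ccc(C(=O)NO)cc1)c1ncc(-c2ccc(C)cc2)s1` has not been measured in this assay. Its difference from compound 1 is ethyl in place of phenyl on a saturated chain carbon bound to a nitrogen on an aromatic ring; the same difference, cut one bond further out, reads benzyl to propyl. The measured step that bears most directly on it is a 7.1-fold lower number from compound 1 to compound 2 (0.85 log units; beyond the scatter), where methyl replaced phenyl at the same place; the step of a 12-fold lower number from compound 1 to compound 3 (1.07 log units; beyond the scatter) points the same way with a different group entering. Both leave the phenyl behind and both lower the number by a modest to large amount. A step of similar size, downward, is expected here.

Compound 4 is therefore expected to give about 6500 nM in this assay, within a range of 2500 nM to 18000 nM. That estimate means a 7.5-fold lower number from compound 1 to compound 4 (0.88 log units; beyond the scatter), expected to be beyond the scatter.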

Compound 4, concentration for 50% growth inhibition: 5800 nM
Compound 4: middle estimate off by 1.1-fold (0.05 log units), on the high side; the measured number falls inside the stated range.
By their numbers in this assay, from the lowest: compounds 3, 4 and 2 (each within the scatter of the next); then compound 1.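

Ethyl in place of phenyl gives an 8.4-fold lower number from compound 1 to compound 4 (0.92 log units; beyond the scatter) and so brings compound 4 to 5800 nM in this assay with a second small saturated chain, which shows that the lower number seen with methyl at this place is not confined to that one group. Methyl in place of hydrogen on the chain gives a 1.2-fold lower number from compound 2 to compound 4 (0.07 log units; within the scatter) and hydrogen in place of phenoxy gives a 1.4-fold higher number from compound 3 to compound 4 (0.15 log units; within the scatter) and both steps lie within the scatter, so compounds 2, 3 and 4 are not separated and neither the extra chain carbon nor the phenoxy end changes the reading here. Among the four compounds only compound 1 stands apart, and compound 3 goes against any reading that a phenyl ring anywhere in this substituent gives the higher number, since its ring sits further out on the chain. No measurement at hand gives a reason for these steps.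

On these data alone, whether a longer chain such as hexyl moves the number away from the level shared by compounds 2, 3 and 4 stays open. Also open, as far as these compounds go, is how a chain ending in an amine or a carboxylic acid would read at this place.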